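The source may report more compounds than this note shows. Statements on the series, on what has been measured and on what is new or still open speak of the compounds shown alone.

In a functional assay on CCRF-CEM cells (Homo sapiens) for cytotoxicity, read by XTT assay, with a stated time of 3 days (on this read-out higher numbers stand for weaker inhibition and lower numbers for stronger inhibition), compound 1 `OC[C@H]1O[C@@H](n2cc(Cl)c3c(-c4ccccc4)ncnc32)[C@H](O)[C@@H]1O` gives 910 nM, and compound 2 `OC[C@H]1O[C@@H](n2cc(Cl)c3c(-c4ccco4)ncnc32)[C@H](O)[C@@H]1O` gives 3800 nM. Compound 2 thus stands at the higher of the two numbers measured, separated from compound 1 by a step beyond the scatter. Compound 3 `OC[C@H]1O[C@@H](n2cc(Cl)c3c(-c4cccs4)ncnc32)[C@H](O)[C@@H]1O` differs from compound 2 as follows: thiophen-2-yl in place of furan-2-yl on an aromatic carbon. Among the compounds with values here, no measured step covers an exchange of one five-membered aromatic ring for another; the only step known is a 4.2-fold higher number from compound 1 to compound 2 (0.62 log units; beyond the scatter), which bears on it indirectly. Compound 3 is therefore expected to lie between those two numbers, the expected step being a 2.1-fold lower number from compound 2 to compound 3 (0.32 log units; beyond the scatter). The estimate for compound 3 is 1800 nM, within 600 nM to 5000 nM.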

Compound 3, half-maximal inhibitory concentration: 2700 nM
For compound 3 the middle estimate is 1.5-fold (0.18 log units) below the measured one; the measured number falls inside the stated range.
By their numbers in this assay, from the lowest: compound 1; then compounds 3 and 2 (each within the scatter of the next).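

Exchanging furan-2-yl for thiophen-2-yl on this aromatic carbon gives a 1.4-fold lower number from compound 2 to compound 3 (0.15 log units; within the scatter) in this assay and so does not separate the two five-membered aromatic rings. Thiophen-2-yl in place of phenyl gives a 3.0-fold higher number from compound 1 to compound 3 (0.47 log units; beyond the scatter) and so, like furan-2-yl, stands apart from phenyl, leaving compound 1 with the lowest number of the three. Nothing measured here accounts for these results.

From the compounds shown here alone, it remains open how an amine, a pyridine ring or a longer alkyl chain on this carbon would read in this assay and whether any would match phenyl.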